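Methoxy on the Indole Core: Cytotoxicity in Neuroblastoma Cells

A few compounds are considered here, and "the series" means these few. Any claim that something is new, unique, unknown or untested is made for them only; others in the source may bear on it.

Compound 1 `COc1ccc(C(=O)N2CCN(CC(=O)N3CCN(CCCc4c[nH]c5ccccc45)CC3)CC2)cc1`: 148000 nM
Compound 2 `O=C(CN1CCN(C(=O)c2ccc(F)cc2)CC1)N1CCN(CCCc2c[nH]c3ccccc23)CC1`: 188000 nM
Compound 3 `O=C(CN1CCN(C(=O)c2cccc(F)c2)CC1)N1CCN(CCCc2c[nH]c3ccccc23)CC1`: 165000 nM

Three compounds share a core and differ only in the aryl group on the carbonyl carbon. In an ADME assay on SH-SY5Y cells (Homo sapiens) for cytotoxicity, read by MTT assay, with a stated time of 72 h (on this read-out higher numbers stand for weaker inhibition and lower numbers for stronger inhibition), compound 1 gives 148000 nM, and its two neighbours lie within the usual scatter of it: a 1.3-fold higher number from compound 1 to compound 2 (0.10 log units; within the scatter) and a 1.1-fold higher number from compound 1 to compound 3 (0.05 log units; within the scatter). Likewise a 1.1-fold lower number from compound 2 to compound 3 (0.06 log units; within the scatter). On these numbers compound 1 is not separated from either other compound.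

Compound 4 `COc1ccc(C(=O)N2CCN(CC(=O)N3CCN(CCCc4c[nH]c5ccc(OC)cc45)CC3)CC2)cc1` is not yet measured in this assay. Relative to compound 1 it carries methoxy in place of hydrogen on an aromatic carbon, on an aromatic carbon of a six-membered aromatic ring of carbon only, part of a fused or bridged system of two rings. For the measured compounds named here, none of the measured steps touches that ring; all of them alter the aryl group on the carbonyl carbon, and each stayed within the scatter. Going by the values given here, there is therefore no measured step that speaks directly to this change, and the only guide is that the series so far has moved little.

On that basis the step is expected to be a 1.0-fold higher number from compound 1 to compound 4 (0.01 log units; within the scatter), which means no change beyond the scatter. Compound 4 is estimated at 150000 nM in this assay, with a range from 75000 nM to 300000 nM.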

Compound 4, half-maximal inhibitory concentration: 190000 nM
The estimate for compound 4 lay 1.3-fold (0.10 log units) below the measured number; the range from low to high includes it.
By their numbers in this assay, from the lowest: compounds 1, 3, 2 and 4 (each within the scatter of the next).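

Compound 4 is the only compound shown that is changed on the six-membered aromatic ring of the fused system rather than on the aryl group on the carbonyl carbon, and in this assay methoxy in place of hydrogen there gives a 1.3-fold higher number from compound 1 to compound 4 (0.11 log units; within the scatter). This place, meta to a fused ring and para to a fused ring, therefore accepts the change from 1H-indol-3-yl to 5-methoxy-1H-indol-3-yl with no shift that can be told from the scatter, so the flat picture seen across the aryl groups now reaches a second site, at least for these four compounds. Nothing measured here explains this result.

The compounds shown leave open whether this holds only for methoxy or also for a different group on the same carbon, such as a hydroxyl, an amine or a carboxylic acid. They also leave open whether the 5-methoxy-1H-indol-3-yl group would give the same result alongside the 4-fluorophenyl or 3-fluorophenyl group, and whether a longer chain to the indole would shift the number in this assay.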